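The compounds below may be only part of what the source reports. "The series", "measured", "known", "first", "only" and "open" are said of these compounds alone.

Compound 3 `CCc1ccc(-n2cc(CNC(=O)c3cccc4c3cnn4C(C)C)nn2)cc1` holds the lowest of the two numbers shown in a functional assay on PC-3 cells (Homo sapiens) for inhibition, read by MTT assay, with a stated time of 72 h (a higher number here means a weaker inhibitor, a lower number a stronger inhibitor), where compound 3 gives 26600 nM. Its nearest neighbour is compound 2 `Cc1cccc(-n2cc(CNC(=O)c3cccc4c3cnn4C(C)C)nn2)c1`, which in this assay gives 32300 nM; the step between them is a 1.2-fold lower number from compound 2 to compound 3 (0.08 log units; within the scatter). Compound 1 `CC(C)n1ncc2c(C(=O)NCc3cn(-c4ccc([N+](=O)[O-])cc4)nn3)cccc21` in this assay reaches only a limit, > 40000 nM, as noted in the limit of > 40000 nM in this assay, at which 1 of the 3 values shown sits. From compound 1 the measured steps are an at least 1.2-fold lower number from compound 1 to compound 2 (0.09 log units; that floor lies within the scatter) and an at least 1.5-fold lower number from compound 1 to compound 3 (0.17 log units; that floor lies within the scatter).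

Compound 4 `CC(C)n1ncc2c(C(=O)NCc3cn(Cc4ccccc4)nn3)cccc21` differs from compound 3 by benzyl in place of 4-ethylphenyl on an aromatic nitrogen. All three measured steps alter the same group on that aromatic nitrogen, and none of them moves the number beyond the scatter; the change to compound 4 is of the same kind. The step in this assay from compound 3 to compound 4 is therefore expected to be a 1.1-fold higher number from compound 3 to compound 4 (0.05 log units; within the scatter), that is, no shift beyond the scatter. Compound 4 is accordingly estimated to give 30000 nM in this assay, with a range from 12000 nM to 75000 nM.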

Compound 4, half-maximal inhibitory concentration: 4420 nM
For compound 4 the middle estimate is 6.8-fold (0.83 log units) above the measured one; the measured number lies below the stated range.
By their numbers in this assay, from the lowest: compound 4; then compounds 3 and 2 (each within the scatter of the next). At a limit, above all of these: compound 1.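

In this assay, among the compounds shown here, the group on this aromatic nitrogen turns out to matter: benzyl in place of 4-ethylphenyl gives a 6.0-fold lower number from compound 3 to compound 4 (0.78 log units; beyond the scatter), and benzyl in place of 3-methylphenyl gives a 7.3-fold lower number from compound 2 to compound 4 (0.86 log units; beyond the scatter), whereas the steps among the earlier compounds all stayed within the scatter. Benzyl in place of 4-nitrophenyl gives an at least 9.0-fold lower number from compound 1 to compound 4 (0.95 log units; beyond the scatter), a floor rather than a measured size. Compound 1 stands only at a limit: the limit of > 40000 nM in this assay, at which 1 of the 4 values shown sits.

Compound 4 is the only benzyl compound shown, and it leaves open whether the lower number survives a methyl, ethyl or nitro group on the benzyl ring. Also open, going by these compounds, is what a longer chain such as phenethyl, or a saturated ring such as cyclohexylmethyl, would do on the same nitrogen.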